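Removing tert-butoxycarbonyl from compound 3: an expected step

This account rests on a few compounds, and the source may have more. Where it says the series, first, only, none or still open, it means among the compounds named here.

In a functional assay on B16 cells (Mus musculus) for inhibition (a higher number here means a weaker inhibitor, a lower number a stronger inhibitor), the series reads:

Compound 1 `O=C(/C=C/c1ccc(O)c(O)c1)NC1CCCC1` gives 30000 nM
Compound 2 `COc1ccccc1CNC(=O)/C=C/c1ccc(O)c(O)c1` gives 7000 nM
Compound 3 `CC(C)(C)OC(=O)N1CCN(C(=O)/C=C/c2ccc(O)c(O)c2)CC1` gives 5800 nM

Compound 3 (5800 nM) lies within the scatter of compound 2 (7000 nM), so these two are not separated. Compound 1 (30000 nM) carries a higher number than compound 3, beyond the scatter.

Compound 4 `O=C(/C=C/c1ccc(O)c(O)c1)N1CCNCC1` is still to be measured in this assay and departs from compound 3 in one place (hydrogen in place of tert-butoxycarbonyl on an amine nitrogen in a ring): hydrogen in place of tert-butoxycarbonyl on an amine nitrogen in a ring.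

Among the compounds with values here, no measured pair differs in a single place, so this change has no direct precedent. Compound 3 alone bears the tert-butoxycarbonyl, while compound 1 (30000 nM) and compound 2 (7000 nM) both lack it and still lie apart, so the data offer only weak guidance. A modest move toward a higher number is expected, within the spread of the three values, though no change beyond the scatter remains possible. The expected change is a 2.4-fold higher number from compound 3 to compound 4 (0.38 log units; beyond the scatter) and would mean a weaker inhibitor. For compound 4 the estimated value is 14000 nM, with an expected range from 4000 nM to 45000 nM.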

Compound 4, half-maximal inhibitory concentration: > 40000 nM
Compound 4 ended at the assay's limit; the forecaster's own chance of this, stated with the estimate: 15%; at least 2.8-fold (0.45 log units) between middle value and limit.
By their numbers in this assay, from the lowest: compounds 3 and 2 (each within the scatter of the next); then compound 1. At a limit, above all of these: compound 4.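

In this assay compound 4 gives > 40000 nM, which is a limit of the assay and not a number. Within the data shown here, replacing tert-butoxycarbonyl with hydrogen on the amine nitrogen in the ring gives an at least 6.8-fold higher number from compound 3 to compound 4 (0.83 log units; beyond the scatter), the first single-place step, and it shows that inhibition in this assay depends on what this nitrogen carries, something no earlier pair could show. The second step, piperazin-1-yl in place of cyclopentylamino on a carbonyl carbon, reads an at least 1.3-fold higher number from compound 1 to compound 4 (0.12 log units; that floor lies within the scatter), and that floor alone does not separate the two compounds: the limit of > 40000 nM in this assay, at which 1 of the 4 values shown sits.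

The compounds shown hold nothing between hydrogen and tert-butoxycarbonyl on this nitrogen, so it stays open whether the whole group is needed or only some part of it. As far as these compounds go, an acetyl, a methyl or a benzyl on the same nitrogen would test whether a group other than tert-butoxycarbonyl can keep the level of compound 3 at 5800 nM, and the true size of the step also remains unknown.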